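The source may hold more compounds than are shown below. What is called first, only, known or untested is meant among the compounds shown, and "the series" means these compounds.

For the measured compounds named here, compound 2 `O=C(Nc1cccc(-c2oc3cc(-c4ccc(F)cc4)ccc3c(=O)c2O)c1)c1cccc(F)c1` gives 15500 nM in a functional assay on HepG2 cells (Homo sapiens) for antiproliferative activity, read by CCK-8 assay, with a stated time of 72 h (a lower number here means a stronger inhibitor, a higher number a weaker inhibitor), the highest of the two numbers measured so far; its only neighbour, compound 1 `Cc1ccc(C(=O)Nc2cccc(-c3oc4cc(-c5ccc(F)cc5)ccc4c(=O)c3O)c2)cc1`, gives 2320 nM in this assay. Going by the values given here, the one measured step, a 6.7-fold higher number from compound 1 to compound 2 (0.82 log units; beyond the scatter), showed that swapping the ring on the carbonyl carbon can move this assay appreciably. Compound 3 `O=C(Nc1cccc(-c2oc3cc(-c4ccc(F)cc4)ccc3c(=O)c2O)c1)c1ccc([N+](=O)[O-])cc1` differs from compound 2 by 4-nitrophenyl in place of 3-fluorophenyl on a carbonyl carbon. Among the compounds with values here, no measured step covers a 4-nitrophenyl group, so its direction is open; a step of similar size in either direction seems possible. Compound 3 is expected to give roughly 7000 nM in this assay, within 1500 nM to 30000 nM, a change of a 2.2-fold lower number from compound 2 to compound 3 (0.35 log units; beyond the scatter).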

Compound 3, half-maximal inhibitory concentration: 1860 nM
For compound 3 the middle estimate is 3.8-fold (0.58 log units) above the measured one; the measured number falls inside the stated range.
By their numbers in this assay, from the lowest: compounds 3 and 1 (each within the scatter of the next); then compound 2.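

In this assay the 4-nitrophenyl group in place of 3-fluorophenyl on a carbonyl carbon gives an 8.3-fold lower number from compound 2 to compound 3 (0.92 log units; beyond the scatter) and recovers what compound 2 had lost. Nitro in place of methyl on an aromatic carbon gives a 1.2-fold lower number from compound 1 to compound 3 (0.10 log units; within the scatter) and so does not separate these two compounds, which leaves compound 2 as the one that stands apart. Nothing available explains this result. The compounds shown leave open whether the gap follows the group itself or where it sits on the ring, since 3-fluorophenyl differs from the other two in both. Going by these compounds, a 4-fluorophenyl or 3-nitrophenyl group would separate these, and an unsubstituted phenyl or an amine on the ring remains untested here.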